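A few compounds are considered here, and "the series" means these few. Any claim that something is new, unique, unknown or untested is made for them only; others in the source may bear on it.

Compound 1 `CCCCCCCCCCCCCCCCCCNC(=O)[C@@H](N)[C@@H](C)O`: 44500 nM
Compound 2 `CCCCCCCCCCCCNC(=O)[C@@H](NC(=O)c1cc2ccccc2n1C)[C@@H](C)O`: > 200000 nM

For the measured compounds named here, in a functional assay on HepG2 cells (Homo sapiens) for cytotoxicity, read by MTT assay, with a stated time of 48 h (a lower number here means a stronger inhibitor, a higher number a weaker inhibitor), compound 1 gives 44500 nM, the only plain number among the values shown. Compound 2 reaches only a limit of the assay, > 200000 nM, matching (the limit of > 200000 nM in this assay, at which 1 of the 2 values shown sits). Compound 3 `CCCCCCCCCCCCCCCCCCNC(=O)[C@@H](NS(=O)(=O)c1ccc(C)cc1)[C@@H](C)O` is not yet measured; it differs from compound 1 by (4-methylphenyl)sulfonyl in place of hydrogen on an amine nitrogen. No step between measured compounds is shown, so the size of this change is open. Compound 2, which also carries a substituent on that nitrogen, gives only the limit > 200000 nM, so a weakening step is expected. The expected step is a 2.5-fold higher number from compound 1 to compound 3 (0.39 log units; beyond the scatter). Compound 3 is estimated at 110000 nM, between 30000 nM and 300000 nM.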

Compound 3, half-maximal inhibitory concentration: 75800 nM
Compound 3: the middle estimate sits 1.5-fold (0.16 log units) above what was measured, within the range that was stated.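

In this assay, (4-methylphenyl)sulfonyl in place of hydrogen on the amine nitrogen gives a 1.7-fold higher number from compound 1 to compound 3 (0.23 log units; within the scatter). So this nitrogen can carry that group with no change in the reading beyond the usual scatter. Compound 2 stays a limit of the assay and differs from compound 1 in more than one place, so it cannot size this change: the limit of > 200000 nM in this assay, at which 1 of the 3 values shown sits.

Still open, going by these compounds, is whether an acetyl group or a methyl group on this nitrogen would give a similar reading. Also open, on these data alone, is whether the same sulfonyl group behaves alike on a shorter chain.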